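The compounds below may be only part of what the source reports. "The series", "measured", "known", "first", "only" and "open" are said of these compounds alone.

The compounds measured so far:

Compound 1 `Cc1nc(-c2cccnc2)sc1-c1nnc(-c2ccc(Br)cc2)o1`. In an ADME assay on PANC-1 cells (Homo sapiens) for cytotoxicity, read by MTT assay (a lower number here means that less compound is tolerated, a higher number that more compound is tolerated), compound 1 reaches only the assay limit > 100 ug/mL.
Compound 2 `Cc1nc(-c2cccnc2)sc1-c1nnc(Cc2ccccc2)o1`. In this assay compound 2 likewise gives only the limit > 100 ug/mL.
Compound 3 `Cc1nc(-c2cccnc2)sc1-c1nnc(-c2cccc(Cl)c2Cl)o1`. In this assay compound 3 also stands at the limit > 100 ug/mL.

Compound 3 therefore stands where the other two stand, at the limit of > 100 ug/mL in this assay, at which 3 of the 3 values shown sit, and no number separates it from compound 1 or compound 2. The steps among the three, a step that the two limits leave unreadable from compound 1 to compound 2, a step that the two limits leave unreadable from compound 1 to compound 3 and a step that the two limits leave unreadable from compound 2 to compound 3, give neither a size nor a direction.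

Compound 4 `Cc1cccc(-c2nnc(-c3sc(-c4cccnc4)nc3C)o2)c1` differs from compound 3 in one place: 3-methylphenyl in place of 2,3-dichlorophenyl on an aromatic carbon. Among the measured compounds shown here, the steps that bear on this exchange are those from compound 1 to compound 3 and from compound 2 to compound 3, since each also swaps the group on the same aromatic carbon, and both were left unreadable by the limits. Nothing in the measured series suggests that any group at this position brings the value below the limit. Compound 4 is thus expected to show no step beyond the scatter, with an estimated step that the limit leaves unreadable from compound 3 to compound 4. The estimate for compound 4 in this assay is 150 ug/mL, expected to fall between 80 ug/mL and 300 ug/mL.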

Compound 4, half-maximal cytotoxic concentration: > 100 ug/mL
Compound 4 gave a limit, no number; the forecaster's own chance of this, stated with the estimate: 85%; the middle value lies beyond the limit too.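

In this assay compound 4 gives only a limit, > 100 ug/mL. Its steps to compound 1, compound 2 and compound 3 cannot be read, and all four compounds stand at the same limit: the limit of > 100 ug/mL in this assay, at which 4 of the 4 values shown sit. The compounds shown leave open how far these four differ, and whether any group on this aromatic carbon would give a readable number.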